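A few compounds are considered here, and "the series" means these few. Any claim that something is new, unique, unknown or untested is made for them only; others in the source may bear on it.

In a functional assay on HCT-116 cells (Homo sapiens) for antiproliferative activity, read by MTT assay, with a stated time of 48 h (a higher number here means a weaker inhibitor, a lower number a stronger inhibitor), compound 1 (`CCCC(CCO)n1cnc2c(Cl)nc(F)nc21`) gives 16500 nM. On these data alone, compound 2 (`CCCC(CCO)n1cnc2c(Cl)ncnc21`) gives > 50000 nM, which is a limit of the assay and not a number, so its true position is unknown. Compound 3 (`CCCCCCC(CCO)n1cnc2c(Cl)ncnc21`) extends the chain of compound 2, with this difference: propyl in place of hydrogen on a saturated chain carbon, four bonds along the chain from an aromatic nitrogen.

Among the compounds with values here, the only measured step, an at least 3.0-fold higher number from compound 1 to compound 2 (0.48 log units; beyond the scatter), is a different change, hydrogen in place of fluoro on an aromatic carbon, so it bears on this one only indirectly. Within the data shown here, no measured step covers the chain. A modest move toward a lower number in this assay is expected, though a second limit remains quite possible. The expected step is an at least 2.0-fold lower number from compound 2 to compound 3 (0.30 log units; that floor lies within the scatter). For compound 3 the estimated value is 25000 nM, with an expected range of 8000 nM to 70000 nM.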

Compound 3, half-maximal inhibitory concentration: 11900 nM
The estimate for compound 3 lay 2.1-fold (0.32 log units) above the measured number; the measured number falls inside the stated range.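

In this assay the saturated chain carbon four bonds along from an aromatic nitrogen responds to substitution: propyl in place of hydrogen there gives an at least 4.2-fold lower number from compound 2 to compound 3 (0.62 log units; beyond the scatter) and brings the series back from a limit to a measured number. Within the data shown here, this is the first measured change on the chain, so the number moves with the chain as well as with fluoro on the aromatic carbon. The true size of the step remains unknown, because compound 2 stands at a limit of the assay and not at a number: the limit of > 50000 nM in this assay, at which 1 of the 3 values shown sits.

Only hydrogen and propyl are compared at this place, which leaves open whether a longer chain such as octyl continues the trend or an amine at the chain end keeps it. Also open, on these data alone, is how fluoro on the aromatic carbon would combine with propyl on the chain.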